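A few compounds are considered here, and "the series" means these few. Any claim that something is new, unique, unknown or untested is made for them only; others in the source may bear on it.

Measured so far:
Compound 1, `COc1cc(OC)c(OC)cc1/C=C/C(=O)c1ccc(OC)c2c1OC(C)(C)C=C2` — > 10000 nM
Compound 2, `CCN(CC)c1ccc(/C=C/C(=O)c2ccc(OC)c3c2OC(C)(C)C=C3)cc1` — 590 nM
Compound 3, `COc1ccc(C(=O)/C=C/c2cccc([N+](=O)[O-])c2)c2c1C=CC(C)(C)O2` — 2830 nM

Of the compounds shown here, three sharing one core have been tested in a functional assay on HepG2 cells (Homo sapiens) for antiproliferative activity, read by MTT assay, with a stated time of 24 h; a higher number here means a weaker inhibitor, a lower number a stronger inhibitor. Compound 1 gives only a limit of the assay, > 10000 nM; the evidence the limit of > 10000 nM in this assay, at which 1 of the 3 values shown sits, shows that one of the three values sits there. Compound 2 gives 590 nM, and compound 3 gives 2830 nM. Of the two proper numbers, compound 3 holds the higher one; its gap to compound 2 lies beyond the scatter of the assay.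

Compound 4, `COc1ccc(C(=O)/C=C/c2cc(Cl)ccc2O)c2c1C=CC(C)(C)O2`, has not yet been measured in this assay. It differs from compound 3 in one place:
5-chloro-2-hydroxyphenyl in place of 3-nitrophenyl on a double-bonded chain carbon bound to a double-bonded chain carbon

Among the compounds with values here, no step between measured compounds has the same change, so the direction is open. Given that the values of compound 2 and compound 3 both sit well clear of the limit, compound 4 is expected to remain in a similar region, with a step of a 1.1-fold higher number from compound 3 to compound 4 (0.03 log units; within the scatter) that need not exceed the scatter. Compound 4 is therefore estimated at 3000 nM, within 800 nM to 12000 nM.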

Compound 4, half-maximal inhibitory concentration: 6640 nM
Estimate against measurement, compound 4: 2.2-fold (0.35 log units) below; the measured number falls inside the stated range.
By their numbers in this assay, from the lowest: compound 2; then compound 3; then compound 4. At a limit, above all of these: compound 1.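

In this assay, exchanging the 3-nitrophenyl group for 5-chloro-2-hydroxyphenyl gives a 2.3-fold higher number from compound 3 to compound 4 (0.37 log units; beyond the scatter). Within the data shown here, this is the first step between compounds that differ in one place, and it shows that the group at this position affects the read-out: of these two groups, 3-nitrophenyl gives the stronger inhibitor, although the step is modest. The change removes the nitro group and adds both a chlorine and a hydroxyl, and nothing measured here accounts for the step or divides it among these parts.

The compounds shown leave open whether the chlorine or the hydroxyl matters more for the step. They also leave open how this position would respond to an unsubstituted phenyl, or to a phenyl carrying an amine or a carboxylic acid.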